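Swapping the pyrimidine for a chloropyridine on the amine

This account rests on a few compounds, and the source may have more. Where it says the series, first, only, none or still open, it means among the compounds named here.

Three compounds measured in a functional assay on HEK293 cells for antagonist activity at Orexin receptor type 2 (Homo sapiens), read by FLIPR and calcium flux (on this read-out higher numbers stand for higher potency (the scale is a negative logarithm) and lower numbers for lower potency), share an amide-linked spirocyclic core and differ mainly in the heteroaryl group on the amine nitrogen. Compound 1 `Cc1nc(C(=O)N2CC3(CC3)C[C@H]2CNc2ncc(Cl)cn2)c(-c2ccccc2)s1` gives 6.8. Compound 2 `Cc1cc(C)nc(NC[C@@H]2CC3(CC3)CN2C(=O)c2nc(C)sc2-c2ccccc2)n1` gives 8.6, the highest of the three numbers; compound 3 `O=C(c1nc(C(F)(F)F)ccc1-c1ncccn1)N1CC2(CC2)C[C@H]1CNc1ccc(C(F)(F)F)cn1`, which also carries a different core, gives 5. For the measured compounds named here, the single matched step among them runs a number 1.80 log units higher from compound 1 to compound 2 (beyond the scatter).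

The unmeasured compound 4 `Cc1nc(C(=O)N2CC3(CC3)C[C@H]2CNc2ccc(Cl)cn2)c(-c2ccccc2)s1` differs from compound 2 in one place: 5-chloropyridin-2-yl in place of 4,6-dimethylpyrimidin-2-yl on an amine nitrogen. The change removes the 4,6-dimethylpyrimidin-2-yl group that, in the step from compound 1 to compound 2, went with the large gain, and puts in a 5-chloropyridin-2-yl group that resembles the 5-chloropyrimidin-2-yl of compound 1 more closely than it resembles the group in compound 2. Going by the values given here, the only step that bears on this is that large one, and it points the other way here. Compound 4 is therefore expected to lose potency, with a step of about a number 1.60 log units lower from compound 2 to compound 4 (beyond the scatter), landing nearer to compound 1 than to compound 2. The estimate for compound 4 in this assay is 7, with a range from 6.3 to 7.7.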

Compound 4, negative logarithm of the antagonist equilibrium constant: 7.1
The estimate for compound 4 lay 0.10 log units below the measured number, and the stated range covers the measured number.
By their numbers in this assay, from the lowest: compound 3; then compounds 1 and 4 (each within the scatter of the next); then compound 2.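

In this assay, putting 5-chloropyridin-2-yl in place of 4,6-dimethylpyrimidin-2-yl on the amine nitrogen gives a number 1.50 log units lower from compound 2 to compound 4 (beyond the scatter), a second large step at this position, and this time with a different chlorine-bearing ring on the losing side. Comparing the two chlorine-bearing rings gives a number 0.30 log units higher from compound 1 to compound 4 (within the scatter), so with 5-chloropyridin-2-yl and 5-chloropyrimidin-2-yl the assay does not separate a ring with one hetero atom from a ring with two. Among these matched compounds, the high number therefore belongs only to the 4,6-dimethylpyrimidin-2-yl group, and nothing available accounts for the size of the steps.

Compound 2 differs from compounds 1 and 4 both in carrying two methyl groups and in lacking chlorine, so the compounds shown do not say which of these goes with its higher number. Going by these compounds, an unsubstituted pyrimidin-2-yl group, or a pyrimidine with a single methyl group, on the same amine nitrogen would bear on that question, and whether a pyridine carrying two methyl groups would match the pyrimidine also remains open.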